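Trifluoromethyl to Cyano on the Sulfonyl Aryl Ring

A few compounds are considered here, and "the series" means these few. Any claim that something is new, unique, unknown or untested is made for them only; others in the source may bear on it.

Measured compounds:
Compound 1 `COC(=O)CC(=O)N1N=C(c2ccc(-n3cncn3)cc2)CC1c1ccc(N(C)C)cc1` — 6.8%
Compound 2 `CN(C)c1ccc(C2CC(c3ccc(-n4cncn4)cc3)=NN2S(=O)(=O)c2ccc(C(F)(F)F)cc2)cc1` — 15.3%

Of the compounds shown here, two sharing one core have been tested in a functional assay on MDA-MB-231 cells (Homo sapiens) for inhibition, read by sulforhodamine B assay, tested at 10 uM; on this read-out lower numbers stand for less inhibition and higher numbers for more inhibition at the one concentration tested (going by the name of the read-out). Compound 1 gives 6.8% in this assay, and compound 2 gives 15.3%. Compound 2 has the higher of the two numbers, but its gap to compound 1 lies within the scatter of repeated measurements, so no order between them can be claimed.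

Compound 3 `CN(C)c1ccc(C2CC(c3ccc(-n4cncn4)cc3)=NN2S(=O)(=O)c2ccc(C#N)cc2)cc1` has not yet been measured in this assay. It differs from compound 2 in one place: cyano in place of trifluoromethyl on an aromatic carbon. Going by the values given here, no step between measured compounds with a related change is available, so there is no measured basis for a shift in either direction. The step from compound 2 to compound 3 in this assay is therefore expected to be none beyond the scatter, a number 2.3 percentage points lower from compound 2 to compound 3 (within the scatter). Compound 3 is estimated to give 13% in this assay, with a range from 0% to 30%.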

Compound 3, a percentage reported as inhibition, at one concentration (the size of the read-out at that concentration, not a potency): 32.8%
The estimate for compound 3 lay 19.8 percentage points below the measured number; measured number outside the range, above it.
By their numbers in this assay, from the lowest: compounds 1 and 2 (each within the scatter of the next); then compound 3.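

In this assay the substituent on the sulfonyl aryl ring proves to matter: going from 4-(trifluoromethyl)phenyl to 4-cyanophenyl gives a number 17.5 percentage points higher from compound 2 to compound 3 (beyond the scatter), so a change at this one aromatic carbon moves the number beyond the scatter, which compound 1 and compound 2 could not show. The (4-cyanophenyl)sulfonyl group in place of ((methoxycarbonyl)methyl)carbonyl on the amine nitrogen in the ring also gives a number 26 percentage points higher from compound 1 to compound 3 (beyond the scatter), a separation that compound 2 did not reach against compound 1. Nothing available explains why cyano behaves differently here.

The compounds shown leave open whether a nitro group, a carboxylic acid or a primary amide on that aromatic carbon would behave like cyano. They also leave open whether the rise would persist with a methoxy group in place of the dimethylamino group of the shared core.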